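A methoxy swap on a pair stuck at the limit

The source may report more compounds than this note shows. Statements on the series, on what has been measured and on what is new or still open speak of the compounds shown alone.

Compound 1 (`COc1cc(-n2ncnc2-c2cccc(Cl)c2)cc(OC)c1OC`) reaches only a limit in a functional assay on A549 cells (Homo sapiens) for antiproliferative activity, read by MTT assay, with a stated time of 72 h (a lower number here means a stronger inhibitor, a higher number a weaker inhibitor), with > 10000 nM as its reading. Compound 2 (`COc1cc(-n2ncnc2-c2cccc(F)c2)cc(OC)c1OC`) also reaches only a limit in this assay with > 10000 nM as its reading. As far as these compounds go, its true potency therefore remains unknown. Among the compounds with values here, the one measured step is a step that the two limits leave unreadable from compound 1 to compound 2 and offers no size to carry forward. Compound 3 (`COc1ccccc1-c1ncnn1-c1cc(OC)c(OC)c(OC)c1`) has 2-methoxyphenyl in place of 3-fluorophenyl on an aromatic carbon of the shared core (2-methoxyphenyl in place of 3-fluorophenyl on an aromatic carbon). Within the data shown here, the only guide is that compound 1 and compound 2 share the limit of > 10000 nM in this assay, at which 2 of the 2 values shown sit, and neither shows a measurable potency, so no clear gain is expected. The expected change is a number no higher from compound 2 to compound 3 (the limit leaves the size open) with its direction unreadable if compound 3 also reaches the limit. For compound 3 the estimated value is 10000 nM (expected range 2500 nM to 30000 nM).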

Compound 3, half-maximal inhibitory concentration: > 10000 nM
Compound 3 was reported as a limit; the forecaster's own chance of this, stated with the estimate: 70%; the middle value lies on the limit itself.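

Compound 3 also gives only a limit, so its steps from compound 1 and from compound 2 cannot be read: the limit of > 10000 nM in this assay, at which 3 of the 3 values shown sit. As far as these compounds go, how strongly compound 1, compound 2 and compound 3 truly act in this assay, and whether swapping the aryl group changes that, stays open.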